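Extending the oxime oxygen of compound 3 with 2-chloroethyl

This account rests on a few compounds, and the source may have more. Where it says the series, first, only, none or still open, it means among the compounds named here.

Measured compounds:
compound 1, `CCO/N=C/Nc1cc(Cl)c(F)c(Cl)c1`, 4 in a physicochemical assay for lipophilicity, measured as octanol-water partition; a lower number here means a more polar compound, a higher number a more lipophilic compound
compound 2, `CCO/N=C/Nc1cc(Cl)c(OCOC)c(Cl)c1`, 3.7 in this assay
compound 3, `C#CCc1c(Cl)cc(N/C=N/O)cc1Cl`, 2.8 in this assay

Compound 3 has the lowest partition coefficient of the three, sitting beyond the scatter under both compound 2 and compound 1. Going by the values given here, the only measured single-point step, a number 0.30 log units lower from compound 1 to compound 2 (within the scatter), changes a substituent on the aromatic ring and stays within the scatter, so it says nothing direct about the oxime oxygen.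

Compound 4, `C#CCc1c(Cl)cc(N/C=N/OCCCl)cc1Cl`, is not yet measured. It differs from compound 3 by 2-chloroethyl in place of hydrogen on an oxygen. Among the compounds with values here, no measured pair shows the same change on this oxygen: compounds 1 and 2 carry an ethyl on that oxygen but also differ from compound 3 in the aromatic substituents, so their values give only indirect guidance. Their higher partition coefficients are in line with a larger group on the oxygen raising the number, but this cannot be separated from the ring differences.

On this basis compound 4 is expected to show a step of a number 1.20 log units higher from compound 3 to compound 4 (beyond the scatter) in this assay, beyond the scatter and upward. The estimate for compound 4 is 4, with a range from 3.5 to 4.5.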

Compound 4, partition coefficient: 3.7
For compound 4 the middle estimate is 0.30 log units above the measured one, within the range that was stated.
By their numbers in this assay, from the lowest: compound 3; then compounds 2, 4 and 1 (each within the scatter of the next).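

The oxygen whose other neighbour is a double-bonded nitrogen now has a measured single-place change of its own: in this assay, 2-chloroethyl in place of hydrogen gives a number 0.90 log units higher from compound 3 to compound 4 (beyond the scatter) at this position. Going by these compounds alone, the only earlier step, a number 0.30 log units lower from compound 1 to compound 2 (within the scatter) on an aromatic carbon, lay within the scatter, so this is the first single-place change in the set that lies beyond it, although it rests on this one pair and on the core of compound 3 alone. Nothing available here accounts for the size of the step.

Within the data shown here, with only one group on this oxygen in a matched pair, the 2-chloroethyl chain cannot be separated into what its carbons and its chlorine each contribute, and the ethyl of compound 1 and compound 2 sits on a different core, so it cannot settle this. From the compounds shown here alone, how an amine, a carboxylic acid or a longer chain on this oxygen would read in this assay remains open, as does whether the same exchange gives a similar step on the core of compound 1.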